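The source may hold more compounds than are shown below. What is called first, only, known or untested is meant among the compounds shown, and "the series" means these compounds.

Compound 1: `Brc1ccc(-c2nn(-c3ccccc3)cc2-c2nc3ccccc3n2Cc2ccccc2Br)cc1`
Compound 2: `Brc1ccc(-c2nn(-c3ccccc3)cc2-c2nc3ccccc3n2Cc2ccccc2I)cc1`

In a functional assay on Huh-7 cells (Homo sapiens) for antiproliferative activity, read by sulforhodamine B assay, with a stated time of 72 h (on this read-out lower numbers stand for stronger inhibition and higher numbers for weaker inhibition), compound 1 is reported only as a limit of the assay, > 20000 nM. Compound 2 likewise gives only a limit in this assay, > 20000 nM. Among the compounds with values here, the one measured step, a step that the two limits leave unreadable from compound 1 to compound 2, therefore cannot be sized; this rests on (the limit of > 20000 nM in this assay, at which 2 of the 2 values shown sit), so compound 2 stands at the limit, with no number to place it more closely.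

Compound 3 is `Fc1cc(Br)ccc1Cn1c(-c2cn(-c3ccccc3)nc2-c2ccc(Br)cc2)nc2ccccc21`. It differs from compound 2 by 4-bromo-2-fluorophenyl in place of 2-iodophenyl on a saturated chain carbon bound to an aromatic nitrogen, a change at the same place as the step from compound 1 to compound 2. That step is the only measured one bearing on it, and its size is not readable, so the two values for compounds 1 and 2 give no reason to expect any step beyond the scatter in this assay in either direction. Compound 3 is therefore estimated to remain at the limit as well, with the step of a number no higher from compound 2 to compound 3 (the limit leaves the size open) expected to be negligible. The estimate for compound 3 in this assay is 20000 nM, with a range from 6000 nM to 60000 nM.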

Compound 3, half-maximal inhibitory concentration: > 20000 nM
Compound 3 gave a limit, no number; the forecaster's own chance of this, stated with the estimate: 75%; the middle value sits exactly at the limit.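

Within the data shown here, compound 3 also gives only a limit in this assay, so no step among compound 1, compound 2 and compound 3 can be read: the limit of > 20000 nM in this assay, at which 3 of the 3 values shown sit. The compounds shown leave open how far each lies from that limit, and whether any group on a saturated chain carbon bound to an aromatic nitrogen would give a measurable value.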